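Chain change on the carbonyl: compound 2 to compound 3

A few compounds are considered here, and "the series" means these few. Any claim that something is new, unique, unknown or untested is made for them only; others in the source may bear on it.

Measured so far in a functional assay on MCF7 cells (Homo sapiens) for antiproliferative activity, read by MTT assay, with a stated time of 72 h (on this read-out lower numbers stand for stronger inhibition and higher numbers for weaker inhibition), for two compounds:
compound 1 (`C/C=C/C(=O)Nc1cccc(Oc2nc(Nc3ccn(C)n3)nc3c2CSCC3)c1`), value (40000 nM)
compound 2 (`CCC/C=C/C(=O)Nc1cccc(Oc2nc(Nc3ccn(C)n3)nc3c2CSCC3)c1`), value (22600 nM)

Going by the values given here, compound 2 (22600 nM) stands within the scatter of compound 1 (40000 nM), its only neighbour, so the two cannot be ranked.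

The next compound, compound 3 (`CC(C)=CC(=O)Nc1cccc(Oc2nc(Nc3ccn(C)n3)nc3c2CSCC3)c1`), carries 2-methylprop-1-en-1-yl in place of pent-1-en-1-yl on a carbonyl carbon. Among the compounds with values here, the group on that carbonyl carbon is also where the one measured step arose. Within the data shown here, that step (a 1.8-fold lower number from compound 1 to compound 2 (0.25 log units; within the scatter)) is the only evidence bearing on this change, and it stays within the scatter. No step beyond the scatter is therefore expected in this assay, and the data favour no direction. The expected step (a 1.3-fold higher number from compound 2 to compound 3 (0.12 log units; within the scatter)) is an estimate set by placing the middle between the two measured values. In this assay compound 3 is expected at 30000 nM within an estimated range of 12000 nM to 70000 nM for a single measurement.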

Compound 3, half-maximal inhibitory concentration: > 50000 nM
Compound 3: no number, only a limit; the forecaster's own chance of this, stated with the estimate: 15%; middle value at least 1.6-fold (0.22 log units) from the limit.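

In this assay compound 3 gives > 50000 nM, which is a limit of the assay and not a number. Even so, the group on the carbonyl carbon now gives its first step beyond the scatter, an at least 2.2-fold higher number from compound 2 to compound 3 (0.34 log units; beyond the scatter), so 2-methylprop-1-en-1-yl and pent-1-en-1-yl can be told apart at this place, which prop-1-en-1-yl and pent-1-en-1-yl could not. The other new step, an at least 1.2-fold higher number from compound 1 to compound 3 (0.09 log units; that floor lies within the scatter), has a floor within the scatter, so those two compounds cannot be ranked and the three groups do not fall into a single order.

Going by these compounds, how far compound 3 lies past its limit stays open, and with it the full size of both new steps: the limit of > 50000 nM in this assay, at which 1 of the 3 values shown sits. Also open is whether a group of another kind on this carbonyl carbon, such as a chain ending in an amine or a chain longer than pent-1-en-1-yl, would shift the number in this assay beyond the scatter in the direction of stronger inhibition.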